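A few compounds are considered here, and "the series" means these few. Any claim that something is new, unique, unknown or untested is made for them only; others in the source may bear on it.

Working notes on the hydroxamic acid series. Compound 1 `Cc1ccc(-c2noc(CCCCCCC(=O)NO)n2)cc1` is the reference point; in a functional assay on NCI-H661 cells (Homo sapiens) for antiproliferative activity, read by MTT assay, with a stated time of 72 h (a lower number here means a stronger inhibitor, a higher number a weaker inhibitor), compound 1 gives 15800 nM. Among the measured compounds shown here, compound 2 `O=C(CCCCCCc1nc(-c2ccc(C(F)(F)F)cc2)no1)NO` is its only measured neighbour, and in this assay compound 2 gives 15300 nM. For the measured compounds named here, the two numbers sit level with each other: the single step on record, a 1.0-fold lower number from compound 1 to compound 2 (0.01 log units; within the scatter), shows that exchanging one aromatic substituent for another on the aryl ring left the read-out unchanged within the scatter. Compound 1 therefore stands alongside compound 2, with no separation between them.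

Compound 3 `O=C(CCCCCCc1nc(-c2cccs2)no1)NO` differs from compound 1 as follows: thiophen-2-yl in place of 4-methylphenyl on an aromatic carbon. This replaces the whole aryl group rather than one substituent on it, so the step from compound 1 to compound 2 bears on it only loosely, and that step was flat. Going by the values given here, no measured step covers an exchange of the aromatic ring itself. The expectation is that the aryl swap moves the read-out no further than the scatter, so compound 3 is expected to show a 1.1-fold lower number from compound 1 to compound 3 (0.02 log units; within the scatter) in this assay. For compound 3 the estimate in this assay is 15000 nM, with a range from 6000 nM to 40000 nM.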

Compound 3, half-maximal inhibitory concentration: 9460 nM
Beside the measured number, compound 3's estimate is 1.6-fold (0.20 log units) above it; measured number inside the range.
By their numbers in this assay, from the lowest: compounds 3, 2 and 1 (each within the scatter of the next).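

In this assay, the exchange at this position, on an aromatic carbon between two ring nitrogen atoms, replaces the whole aryl group rather than one substituent on it and gives a 1.7-fold lower number from compound 1 to compound 3 (0.22 log units; within the scatter). The read-out therefore does not separate compound 3 from compound 1, even though a five-membered aromatic ring with 1 hetero atom enters in place of a six-membered aromatic ring of carbon only, with 5 heavy atoms against 7 and 1 hydrogen-bond acceptor against 0. No supporting measurement accompanies this result, so the data offer no explanation for it.

Going by these compounds, the three compounds lie each within the scatter of the next in this assay, so it remains open whether any change at this position can move the number beyond the scatter, for example a pyridine ring, a saturated cyclohexyl ring or an aryl ring carrying an amine. On these data alone, it also remains open whether a longer chain carrying the hydroxamic acid would shift the read-out more than these aryl exchanges do.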